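Trifluoromethyl for Hydrogen on the Phenoxy Ring

This account rests on a few compounds, and the source may have more. Where it says the series, first, only, none or still open, it means among the compounds named here.

Of the compounds shown here, three built on one shared core have been measured in an assay on SH-SY5Y cells for inhibition of Voltage-dependent N-type calcium channel subunit alpha-1B (Homo sapiens), read by FLIPR and calcium flux, with stated times of 600 s and 300 s, in the presence of a further agent that is not named here; a higher number here means a weaker inhibitor, a lower number a stronger inhibitor. Compound 1 `CN(C)CCCOc1ccc(CN(C)c2nc3ccc(Oc4ccc(C(F)(F)F)cc4)cc3s2)cc1` gives 46000 nM. Compound 2 `CN(Cc1ccc(OCCCN)cc1)c1nc2ccc(Oc3ccc(C#N)cc3)cc2s1` gives 65000 nM, and compound 3 `CN(Cc1ccc(OCCCN)cc1)c1nc2ccc(Oc3ccccc3)cc2s1` gives 49000 nM. On these numbers compound 3 holds the second highest of the three, yet it lies within the scatter of each of the others, so no ordering among them can be read. Within the data shown here, the only single change with two measured ends is a 1.3-fold lower number from compound 2 to compound 3 (0.12 log units; within the scatter), a step that stays inside the scatter.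

Compound 4 `CN(Cc1ccc(OCCCN)cc1)c1nc2ccc(Oc3ccc(C(F)(F)F)cc3)cc2s1` differs from compound 3 by trifluoromethyl in place of hydrogen on an aromatic carbon. Among the measured compounds shown here, no measured pair carries exactly this change, so the step has to be judged from what is at hand. The step of a 1.3-fold lower number from compound 2 to compound 3 (0.12 log units; within the scatter) shows that swapping a group on that aromatic carbon for hydrogen barely moved the number. Compound 1 also carries the trifluoromethyl group on the phenoxy ring, though it differs from compound 4 elsewhere; in this assay compound 1 gives 46000 nM, close to compound 3. Compound 4 is therefore expected to show a step of a 1.1-fold lower number from compound 3 to compound 4 (0.04 log units; within the scatter), nothing beyond the scatter. Compound 4 is expected to give 45000 nM, with a range from 22000 nM to 90000 nM.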

Compound 4, half-maximal inhibitory concentration: 283000 nM
Estimate against measurement, compound 4: 6.3-fold (0.80 log units) below; the measured number lies above the stated range.
By their numbers in this assay, from the lowest: compounds 1, 3 and 2 (each within the scatter of the next); then compound 4.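

In this assay, the step between cyano and hydrogen on this aromatic carbon had stayed within the scatter, but trifluoromethyl stands apart from both groups, with a 5.8-fold higher number from compound 3 to compound 4 (0.76 log units; beyond the scatter) and a 4.4-fold higher number from compound 2 to compound 4 (0.64 log units; beyond the scatter). The 4-(trifluoromethyl)phenoxy group does not set the number on its own, since the two compounds carrying it are separated by the end of the chain: with amino in place of dimethylamino there is a 6.2-fold higher number from compound 1 to compound 4 (0.79 log units; beyond the scatter), so the effect of this change at the aromatic carbon may depend on the amine at the far end of the molecule. Nothing measured here accounts for the rise in the number on adding trifluoromethyl.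

From the compounds shown here alone, it remains open whether a smaller group at this carbon, such as methyl, chlorine or methoxy, would stay with hydrogen and cyano or move with trifluoromethyl. Also open, going by these compounds, is how hydrogen or cyano on the phenoxy ring would read with dimethylamino at the chain end, which would show whether the two changes act independently.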